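The source may hold more compounds than are shown below. What is called first, only, known or untested is meant among the compounds shown, and "the series" means these compounds.

Compound 1 `CCCCCCCCCCCCc1ccc(CO[C@@H]2CN[C@@H](CO)C2)cc1` and compound 3 `CCCCCCCCCCCCCCc1ccc(CO[C@@H]2CN[C@@H](CO)C2)cc1` share one core and differ in a single place. In a functional assay on FL5.12 cells (Mus musculus) for cytotoxicity, read by flow cytometry, with a stated time of 48 h (a higher number here means a weaker inhibitor, a lower number a stronger inhibitor), compound 1 gives 10100 nM, and compound 3 gives 10500 nM. The change between them, (ethyl in place of hydrogen on a saturated chain carbon, ten or more bonds along the chain from an aromatic carbon), produces a 1.0-fold higher number from compound 1 to compound 3 (0.02 log units; within the scatter). Compound 2 `CCCCCCCCCC/C=C/c1ccc(CO[C@@H]2CN[C@@H](CO)C2)cc1` gives 2800 nM in this assay, the lowest of the three numbers; the difference between the core of compound 2 and that of compound 1 is not broken down here, and what the two values show is a gap beyond the scatter. Compound 4 `CCCCCCCCCCCC/C=C/c1ccc(CO[C@@H]2CN[C@@H](CO)C2)cc1` remains to be measured. From compound 2 to compound 4 the change is ethyl in place of hydrogen on a saturated chain carbon, ten or more bonds along the chain from a double-bonded chain carbon. This is the same kind of change as from compound 1 to compound 3, though the place differs: the chain is counted from a double-bonded chain carbon rather than from an aromatic carbon. The expected step in this assay is a 1.0-fold higher number from compound 2 to compound 4 (0.02 log units; within the scatter), because a 1.0-fold higher number from compound 1 to compound 3 (0.02 log units; within the scatter) lies within the scatter. Compound 4 is therefore expected near 2900 nM, between 1200 nM and 7000 nM.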

Compound 4, half-maximal inhibitory concentration: 5100 nM
The estimate for compound 4 lay 1.8-fold (0.25 log units) below the measured number, and the stated range covers the measured number.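

Working notes on the chain extension: in this assay, ethyl in place of hydrogen on a saturated chain carbon, ten or more bonds along the chain from a double-bonded chain carbon, gives a 1.8-fold higher number from compound 2 to compound 4 (0.26 log units; within the scatter). On the two cores shown, the change behaves alike within the resolution of this assay, and the two steps cannot be told apart: the same change on two cores in this assay, a 1.0-fold higher number (0.02 log units; within the scatter) from compound 1 to compound 3 and a 1.8-fold higher number (0.26 log units; within the scatter) from compound 2 to compound 4, 1.8-fold (0.24 log units) apart, within the scatter of two such steps This supports carrying the change between these two cores only, and it does not establish a rule for the series, since it rests on just two matched pairs and says nothing about other cores or other positions on the chain.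

The compounds shown leave open whether a longer chain, or a shorter one, would also stay within the scatter on either core. Also open, on these data alone, is how a chain carrying an amine or a carboxylic acid would read in this assay.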